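The source may hold more compounds than are shown below. What is called first, only, known or untested is meant among the compounds shown, and "the series" means these compounds.

Compound 1 `O=C1/C(=C/c2coc3ccccc3c2=O)N=C(c2ccc(Cl)cc2)N1c1ccc(S(=O)(=O)Nc2nccs2)cc1` sits at the limit of > 100000 nM in this assay, at which 1 of the 2 values shown sits, of a functional assay on A549 cells (Homo sapiens) for cytotoxicity, read by sulforhodamine B assay, with a stated time of 72 h (on this read-out lower numbers stand for stronger inhibition and higher numbers for weaker inhibition), and gives > 100000 nM as a limit rather than a number. Among the compounds with values here, compound 2 `Cc1cc(C)nc(NS(=O)(=O)c2ccc(N3C(=O)/C(=C/c4coc5ccccc5c4=O)N=C3c3ccc(Cl)cc3)cc2)n1` gives 52600 nM in this assay, the only number so far; the step of an at least 1.9-fold lower number from compound 1 to compound 2 (0.27 log units; that floor lies within the scatter) lies within the scatter. Compound 3 `O=C1/C(=C/c2coc3ccccc3c2=O)N=C(c2ccc(Cl)cc2)N1c1ccc(S(=O)(=O)Nc2ccccn2)cc1` carries the change (pyridin-2-yl in place of 4,6-dimethylpyrimidin-2-yl on a sulfonamide nitrogen). Within the data shown here, only the step from compound 1 to compound 2 bears on it, and that step stayed within the scatter, so no movement beyond the scatter is expected in this assay. Compound 3 is estimated at 60000 nM, range 20000 nM to 100000 nM, an expected step of a 1.1-fold higher number from compound 2 to compound 3 (0.06 log units; within the scatter).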

Compound 3, half-maximal inhibitory concentration: > 100000 nM
Compound 3: a limit, no number; the forecaster's own chance of this, stated with the estimate: 40%; middle value at least 1.6-fold (0.22 log units) away from the limit.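

Compound 3 gives a limit in this assay, not a number. The change to pyridin-2-yl on the sulfonamide nitrogen gives an at least 1.9-fold higher number from compound 2 to compound 3 (0.27 log units; that floor lies within the scatter), so a second change at this position also shows no movement beyond the scatter, and the steps between the two limits cannot be read. Values at this position now gather at one end of the read-out: the limit of > 100000 nM in this assay, at which 2 of the 3 values shown sit.

Still open, going by these compounds, is whether a plain phenyl or a methyl on the sulfonamide nitrogen would move the number beyond the scatter. With a single number in the series, no order among these groups can be drawn.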